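The source may report more compounds than this note shows. Statements on the series, on what has been measured and on what is new or still open speak of the compounds shown alone.

Measured so far:
compound 2 `O=[N+]([O-])c1ccc(Nc2cncc(N3CC4CC(C3)N4)c2)cc1` — 0.684 nM
compound 1 `Oc1ccc(Nc2ccc(N3CC4CC(C3)N4)cn2)cc1` — 165 nM

In an assay on HEK293 cells for displacement of a labelled ligand from Neuronal acetylcholine receptor; alpha3/beta4 (Homo sapiens) (a lower number here means a stronger inhibitor, a higher number a weaker inhibitor), compound 2 gives 0.684 nM, the lowest of the two numbers in hand. Its nearest neighbour is compound 1, which in this assay gives 165 nM; the gap between the two lies well beyond the scatter, and since the two compounds differ in more than one place, nothing more can be read from that pair than what the two values show.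

Compound 3 `c1ccc(Nc2cncc(N3CC4CC(C3)N4)c2)cc1` has not yet been measured. It is reached from compound 2 by hydrogen in place of nitro on an aromatic carbon. Going by the values given here, no measured pair shows this change on this core, so the expectation rests on compound 2 alone. Taking the nitro away is expected to move the number upward, toward weaker binding, by a step of a 29-fold higher number from compound 2 to compound 3 (1.47 log units; beyond the scatter), beyond the scatter. Compound 3 is therefore estimated at 20 nM, with a range from 4 nM to 100 nM.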

Compound 3, inhibition constant: 0.799 nM
Estimate against measurement, compound 3: 25-fold (1.40 log units) above; measured number outside the range, below it.
By their numbers in this assay, from the lowest: compounds 2 and 3 (each within the scatter of the next); then compound 1.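

With hydrogen in place of nitro on the aromatic carbon para to a large group, the two compounds read alike in this assay (a 1.2-fold higher number from compound 2 to compound 3 (0.07 log units; within the scatter)). On this core, then, the nitro is not required for a number as low as that of compound 2, something that compound 1 could not show, as it differs from compound 2 in more than one place. Nothing measured here bears on why the two compounds match.

As far as these compounds go, whether an amine, a carboxylic acid or a longer chain at this same place would also read alike remains open. Also open is which part of the structure accounts for the gap to compound 1, which differs from compound 3 in more than one place as well.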